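Oxan-4-yl in place of 4-chloro-3-fluorophenyl

The source may hold more compounds than are shown below. What is called first, only, known or untested is meant among the compounds shown, and "the series" means these compounds.

Of the compounds shown here, three on the shared core have been read in a toxicity assay on Vero cells (Chlorocebus sabaeus) for cytotoxicity; on this read-out higher numbers stand for lower toxicity in this test and lower numbers for higher toxicity in this test: compound 1 (`COc1nc(-c2ccc(Br)cc2)ccc1[C@@H](c1ccccc1)[C@@](O)(CCN(C)C)c1cccc2ccccc12`), compound 2 (`COc1nc(-c2ccc(C(F)(F)F)cc2)ccc1[C@@H](c1ccccc1)[C@@](O)(CCN(C)C)c1cccc2ccccc12`) and compound 3 (`COc1nc(-c2ccc(Cl)c(F)c2)ccc1[C@@H](c1ccccc1)[C@@](O)(CCN(C)C)c1cccc2ccccc12`). Compound 1 gives > 50 ug/mL, which is a limit and not a number. Compound 2 gives > 50 ug/mL, also a limit. Compound 3 gives > 50 ug/mL, again a limit. Compound 3 therefore has no number of its own and stands with the other two: the limit of > 50 ug/mL in this assay, at which 3 of the 3 values shown sit.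

Compound 4 (`COc1nc(C2CCOCC2)ccc1[C@@H](c1ccccc1)[C@@](O)(CCN(C)C)c1cccc2ccccc12`) is next. Its difference from compound 3 is oxan-4-yl in place of 4-chloro-3-fluorophenyl on an aromatic carbon.

Within the data shown here, three measured steps bear on this place: a step that the two limits leave unreadable from compound 1 to compound 3, a step that the two limits leave unreadable from compound 2 to compound 3 and a step that the two limits leave unreadable from compound 1 to compound 2. None of them has a readable size, and all three exchange one substituted phenyl for another. Among the measured compounds shown here, no measured step replaces the phenyl with a non-aromatic ring, so the change to oxan-4-yl is untested. No direction can be drawn from these data, and no step beyond the scatter is expected. The expected step is a step that the limit leaves unreadable from compound 3 to compound 4. With compound 3 reported only as the limit > 50 ug/mL, a report at that same limit is the likeliest outcome for compound 4. In this assay the estimated value for compound 4 is 65 ug/mL, with an expected range from 30 ug/mL to 130 ug/mL.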

Compound 4, half-maximal cytotoxic concentration: > 50 ug/mL
Compound 4 gave a limit, no number; the forecaster's own chance of this, stated with the estimate: 80%; the middle value does not contradict the limit.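

In this assay, among these compounds, compound 4 gives > 50 ug/mL, which is a limit and not a number, so no step from compound 1, compound 2 or compound 3 to compound 4 can be read. All four compounds stand at one value: the limit of > 50 ug/mL in this assay, at which 4 of the 4 values shown sit.

The compounds shown leave open whether any group at this place on the shared core gives a readable value in this assay, and how oxan-4-yl compares with the substituted phenyl groups there.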